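From 4-methoxyphenyl to 3,5-dichlorophenyl: working notes

The source may report more compounds than this note shows. Statements on the series, on what has been measured and on what is new or still open speak of the compounds shown alone.

Of the compounds shown here, two have numbers so far. In a functional assay on HT-1080 cells (Homo sapiens) for cytotoxicity, read by MTT assay, with a stated time of 72 h (on this read-out lower numbers stand for stronger inhibition and higher numbers for weaker inhibition), compound 1 (`COc1ccc(/C=C2\CCC/C(=C\c3cccc(Cl)c3)C2=O)cc1OC`) gives 4900 nM and compound 2 (`COc1ccc(/C=C2\CCC/C(=C\c3ccc(OC)c(OC)c3)C2=O)cc1`) gives 7200 nM on the same read-out. Within the data shown here, the only measured step is a 1.5-fold higher number from compound 1 to compound 2 (0.17 log units; within the scatter) and it leaves compound 2 level with compound 1, so the two cannot be ordered.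

The move to compound 3 (`COc1ccc(/C=C2\CCC/C(=C\c3cc(Cl)cc(Cl)c3)C2=O)cc1OC`) is 3,5-dichlorophenyl in place of 4-methoxyphenyl on a double-bonded chain carbon bound to a double-bonded ring carbon with 3,5-dichlorophenyl in place of 4-methoxyphenyl on a double-bonded chain carbon bound to a double-bonded ring carbon. The measured step concerns this same place, where it exchanged 3-chlorophenyl for 4-methoxyphenyl, and it stayed small. Among the measured compounds shown here, no compound with 3,5-dichlorophenyl has a number yet, so the data do not show what the further chlorine does.

The nearest guide is compound 1 (4900 nM) as it carries 3-chlorophenyl at that place. In this assay only a slight move towards a lower number is expected, estimated as a 1.6-fold lower number from compound 2 to compound 3 (0.20 log units; within the scatter) and so nothing beyond the scatter. For compound 3 the estimated value is 4500 nM (expected range 1500 nM to 12000 nM).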

Compound 3, half-maximal inhibitory concentration: 3000 nM
For compound 3 the middle estimate is 1.5-fold (0.18 log units) above the measured one; the range from low to high includes it.
By their numbers in this assay, from the lowest: compounds 3, 1 and 2 (each within the scatter of the next, the first and the last beyond it).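

Among these compounds, at the place on a double-bonded chain carbon bound to a double-bonded ring carbon, the exchange of 4-methoxyphenyl for 3,5-dichlorophenyl gives the first step that lies beyond the scatter in this assay: a 2.4-fold lower number from compound 2 to compound 3 (0.38 log units; beyond the scatter), though it remains modest. The added chlorine alone does not separate the pair that differs only by chloro in place of hydrogen on an aromatic carbon, since a 1.6-fold lower number from compound 1 to compound 3 (0.21 log units; within the scatter), so those two compounds cannot be ordered and the step beyond the scatter appears only when the 4-methoxyphenyl and 3,5-dichlorophenyl compounds are compared directly. No measured evidence bearing on the origin of this step is available.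

The compounds shown do not separate the loss of the methoxy group from the arrival of the chlorines, so it remains open which part of the exchange carries the step. Also open, going by these compounds, is how this place responds to groups of another kind, such as an unsubstituted phenyl or a phenyl carrying an amine or a carboxylic acid.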